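Cyclopropyl Gives Way to 2-Chlorophenyl on the Shared Core

A few compounds are considered here, and "the series" means these few. Any claim that something is new, unique, unknown or untested is made for them only; others in the source may bear on it.

In a functional assay on K562 cells (Homo sapiens) for antiproliferative activity, read by MTT assay, with a stated time of 48 h (a higher number here means a weaker inhibitor, a lower number a stronger inhibitor), compound 3 `O=C(CCCCCCn1cc(Nc2ncc(Cl)c(NC3CC3)n2)cn1)NO` gives 380 nM, level with compound 1 `O=C(CCCCCCn1cc(Nc2ncc(Cl)c(Nc3cccc(Cl)c3)n2)cn1)NO` at 380 nM, while compound 2 `O=C(CCCCCCn1cc(Nc2ncc(Cl)c(Nc3ccc(F)cc3)n2)cn1)NO` gives 500 nM. Compound 4 `O=C(CCCCCCn1cc(Nc2ncc(Cl)c(Nc3ccccc3Cl)n2)cn1)NO` carries 2-chlorophenyl in place of cyclopropyl on a nitrogen on an aromatic ring. Among the measured compounds shown here, two measured steps bear on this change, with cyclopropyl entering in place of 3-chlorophenyl, no change at the digits printed from compound 1 to compound 3 (within the scatter), and in place of 4-fluorophenyl, a 1.3-fold lower number from compound 2 to compound 3 (0.12 log units; within the scatter). Both lie within the scatter, as does a 1.3-fold higher number from compound 1 to compound 2 (0.12 log units; within the scatter). For the measured compounds named here, no measured compound carries 2-chlorophenyl itself, so no step beyond the scatter is expected in this assay. The estimated step is a 1.1-fold higher number from compound 3 to compound 4 (0.04 log units; within the scatter). Compound 4 is expected at 420 nM, within an estimated range of 190 nM to 950 nM.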

Compound 4, half-maximal inhibitory concentration: 860 nM
Compound 4: the middle estimate sits 2.0-fold (0.31 log units) below what was measured, within the range that was stated.
By their numbers in this assay, from the lowest: compounds 1, 3, 2 and 4 (each within the scatter of the next, the first and the last beyond it).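

In this assay, among the compounds shown here, 2-chlorophenyl is the first group on this nitrogen to move the number beyond the scatter, with a 2.3-fold higher number from compound 3 to compound 4 (0.35 log units; beyond the scatter) and with a 2.3-fold higher number from compound 1 to compound 4 (0.35 log units; beyond the scatter) as well, so 2-chlorophenyl and 3-chlorophenyl do not read alike here. Against 4-fluorophenyl the change stays inside the scatter, at a 1.7-fold higher number from compound 2 to compound 4 (0.24 log units; within the scatter) in this assay. No measurement at hand gives a reason for this shift.

The compounds shown leave open whether 2-fluorophenyl or 2-methylphenyl on this nitrogen would follow 2-chlorophenyl. They also leave open where unsubstituted phenyl would fall among these compounds.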